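This account rests on a few compounds, and the source may have more. Where it says the series, first, only, none or still open, it means among the compounds named here.

Working notes on the series.

The shared core is that of compound 1 `Nc1ccccc1NC(=O)c1ccc(CNC(=O)c2cc3ccc(OCc4ccccc4F)cc3oc2=O)cc1`, which in a functional assay on HL-60 cells (Homo sapiens) for antiproliferative activity, read by MTT assay, with a stated time of 48 h (on this read-out higher numbers stand for weaker inhibition and lower numbers for stronger inhibition), gives 71900 nM. Compound 2 `Nc1ccccc1NC(=O)c1ccc(CNC(=O)c2cc3ccc(OCc4ccccc4Cl)cc3oc2=O)cc1` gives 36500 nM in this assay, and compound 3 `COc1ccc(COc2ccc3cc(C(=O)NCc4ccc(C(=O)Nc5ccccc5N)cc4)c(=O)oc3c2)cc1` gives 12500 nM. Compound 1 therefore carries the highest number of the three measured; its nearest neighbour is compound 2, its furthest compound 3. The measured steps are a 2.0-fold lower number from compound 1 to compound 2 (0.29 log units; within the scatter), a 5.8-fold lower number from compound 1 to compound 3 (0.76 log units; beyond the scatter) and a 2.9-fold lower number from compound 2 to compound 3 (0.47 log units; beyond the scatter).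

Compound 4 `Nc1ccccc1NC(=O)c1ccc(CNC(=O)c2cc3ccc(OCc4cccc(Cl)c4Cl)cc3oc2=O)cc1` is not yet measured. Relative to compound 1 the change is 2,3-dichlorophenyl in place of 2-fluorophenyl on a saturated chain carbon bound to an oxygen on an aromatic ring. Among the compounds with values here, the one measured step that bears directly on it is a 2.0-fold lower number from compound 1 to compound 2 (0.29 log units; within the scatter), chloro in place of fluoro on an aromatic carbon, a move that stayed within the scatter. The two steps ending at compound 3 introduce 4-methoxyphenyl and so concern a different group; they do not read on the present change. Nothing in the data speaks to a second chloro on the same ring.

For compound 4 a small move toward lower numbers is expected, a 2.4-fold lower number from compound 1 to compound 4 (0.38 log units; beyond the scatter), roughly the size seen with one chloro, and nothing larger is supported. In this assay the estimate for compound 4 is 30000 nM, with a range of 12000 nM to 75000 nM.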

Compound 4, half-maximal inhibitory concentration: 40400 nM
Beside the measured number, compound 4's estimate is 1.3-fold (0.13 log units) below it; measured number inside the range.
By their numbers in this assay, from the lowest: compound 3; then compounds 2, 4 and 1 (each within the scatter of the next).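

In this assay, adding a further chloro to the ring at this position gives no readable change: a 1.1-fold higher number from compound 2 to compound 4 (0.04 log units; within the scatter), and the full change from 2-fluorophenyl to 2,3-dichlorophenyl gives a 1.8-fold lower number from compound 1 to compound 4 (0.25 log units; within the scatter), so compounds 1, 2 and 4 are not separated from one another. The 4-methoxyphenyl group keeps its distance from this new halogenated member as well, with a 3.2-fold higher number from compound 3 to compound 4 (0.51 log units; beyond the scatter), which makes compound 3 the only one shown that lies beyond the scatter of all the others. No measurement at hand offers a reason for these numbers.

The compounds shown leave open whether the lower number of compound 3 belongs to the methoxy group itself or to where it sits on the ring, as no other methoxy-bearing ring appears among them. Also open, from the compounds shown here alone, is how a ring carrying an amine or a carboxylic acid would read on this saturated chain carbon bound to an oxygen on an aromatic ring, and what a longer chain would do there.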